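A few compounds are considered here, and "the series" means these few. Any claim that something is new, unique, unknown or untested is made for them only; others in the source may bear on it.

Two compounds carry numbers in an assay on isolated protein for binding affinity to Rap guanine nucleotide exchange factor 4 (Homo sapiens), read by cAMP accumulation; a lower number here means a stronger inhibitor, a higher number a weaker inhibitor. Compound 1 `Cc1cc(C)c(Nc2ccc(Cl)c(C(F)(F)F)c2)c(C)c1` gives 400 nM in this assay. Compound 2 `CCc1cccc(Nc2c(C)cc(C)cc2C)c1` gives 1800 nM in this assay, the higher of the two numbers, and its gap to compound 1 lies beyond the scatter. Compound 3 `Cc1cc(C)c(Nc2cccc(N)c2)c(C)c1` differs from compound 2 by amino in place of ethyl on an aromatic carbon. Within the data shown here, no measured pair shows this change, so the size of the step is open; a small rise, or none beyond the scatter, is expected. The expected step is a 1.4-fold higher number from compound 2 to compound 3 (0.14 log units; within the scatter). Compound 3 is estimated at 2500 nM in this assay, with a range from 800 nM to 8000 nM.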

Compound 3, half-maximal inhibitory concentration: 34000 nM
Estimate against measurement, compound 3: 14-fold (1.13 log units) below; the measured number lies above the stated range.
By their numbers in this assay, from the lowest: compound 1; then compound 2; then compound 3.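

In this assay amino in place of ethyl on an aromatic carbon, meta to a large group, gives a 19-fold higher number from compound 2 to compound 3 (1.28 log units; beyond the scatter) and so moves the series towards a weaker inhibitor. This position therefore does not tolerate every small group, and the exchange, which brings in a hydrogen-bond donor and acceptor, is not neutral here. Nothing available accounts for the size of this step.

From the compounds shown here alone, whether the loss comes from removing ethyl or from adding amino remains open. Also open, going by these compounds, is how a methyl, a methoxy or an acetamide would read at this position on the shared core.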